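A few compounds are considered here, and "the series" means these few. Any claim that something is new, unique, unknown or untested is made for them only; others in the source may bear on it.

Compound 1 `Cc1ccnc(NC(c2ccc3cccnc3c2O)c2c(F)cccc2Cl)c1` was tested in an assay for inhibition of protein disulfide-isomerase (Homo sapiens), with a stated time of 1 h; on this read-out higher numbers stand for weaker inhibition and lower numbers for stronger inhibition. In this assay compound 1 gives > 40000 nM, which is a limit of the assay and not a measured number. Compound 2 `Oc1cc2c(cc1C(c1ccc(F)cc1)N1CCCCC1)CCCC2` likewise gives > 100000 nM in this assay, again a limit rather than a number. Only compound 3 `COc1ccccc1NC(c1ccccc1)c1ccc2cccnc2c1O` gives a finite value, 390 nM in this assay. Compound 1 thus stands at one of the two limits among the three values, with no number of its own to compare against compound 3.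

Compound 4 `Cc1ccnc(NC(c2ccccc2F)c2ccc3cccnc3c2O)c1` differs from compound 1 in one place: hydrogen in place of chloro on an aromatic carbon. Going by the values given here, no pair of measured compounds shows what this change does, so the size of its step in this assay is open. Since compound 1 is known only as a limit, the expected step from compound 1 to compound 4 is taken as none beyond the scatter, which is what a number no higher from compound 1 to compound 4 (the limit leaves the size open) means here. Compound 4 is therefore expected to give about 40000 nM in this assay, with a range from 5000 nM to 200000 nM.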

Compound 4, half-maximal inhibitory concentration: 880 nM
For compound 4 the middle estimate is 45-fold (1.66 log units) above the measured one; measured number below the stated range.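

Exchanging the 2-chloro-6-fluorophenyl group for 2-fluorophenyl gives an at least 45-fold lower number from compound 1 to compound 4 (1.65 log units; beyond the scatter) in this assay, the first step shown for any change in these compounds. A single chlorine on an aromatic carbon, ortho to a large group, thus separates a limit of the assay from a finite value, and the direction is towards stronger inhibition. The full size of the step stays open because compound 1 is known only as a limit: the limit of > 40000 nM in this assay, at which 1 of the 4 values shown sits.

The compounds shown do not tell whether a bromo group, a methyl group or a nitrile at this place would weaken inhibition as chloro does, or whether hydrogen is needed. They also leave open what the remaining fluoro group contributes, and whether the same exchange would have a similar effect on a different core.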